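Pyridinylethoxy replaces fluorophenylpropyl at the tolerated-concentration ceiling

The source may hold more compounds than are shown below. What is called first, only, known or untested is meant among the compounds shown, and "the series" means these compounds.

Compounds 1, 2 and 3 share one core and differ only in the group carried on the outer phenyl ring. Compound 1 is `COc1cccc(CCOc2ccc(-c3c(C)nc(C)c([C@H](OC(C)(C)C)C(=O)O)c3N3CCC(C)(C)CC3)cc2)c1`. In a toxicity assay on MT2 cells (Homo sapiens) for cytotoxicity, read by XTT assay, with a stated time of 4 days (a higher number here means that more compound is tolerated, a lower number that less compound is tolerated), compound 1 gives >= 33500 nM, which is a limit of the assay rather than a number. Compound 2 is `Cc1nc(C)c([C@H](OC(C)(C)C)C(=O)O)c(N2CCC(C)(C)CC2)c1-c1ccc(CCCc2ccc(F)cc2)cc1`. In this assay compound 2 gives >= 32000 nM, again a limit. Compound 3 is `Cc1nc(C)c([C@H](OC(C)(C)C)C(=O)O)c(N2CCC(C)(C)CC2)c1-c1ccc(OC2COCC2c2ccc(F)cc2)cc1`. In this assay compound 3 gives >= 32000 nM; >= 32000 nM (2 entries), also a limit, recorded twice. The step that the two limits leave unreadable from compound 1 to compound 2 is not readable; both of its ends are limits.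

Compound 2 therefore stands only at a limit, and so do its neighbours: the limit of >= 32000 nM in this assay, at which 1 of the 3 values shown sits, and the limit of >= 33500 nM in this assay, at which 1 of the 3 values shown sits, together account for every value shown. Compound 4 is `Cc1nc(C)c([C@H](OC(C)(C)C)C(=O)O)c(N2CCC(C)(C)CC2)c1-c1ccc(OCCc2ccncc2)cc1`. It differs from compound 2 by 2-(pyridin-4-yl)ethoxy in place of 3-(4-fluorophenyl)propyl on an aromatic carbon. Going by the values given here, no measured step bears on this exchange in a readable way, since every value is a limit, so neither a size nor a direction can be drawn from the data. Compound 4 is expected to sit at the same ceiling, with an estimated step of a number no higher from compound 2 to compound 4 (the limit leaves the size open). For compound 4 the estimate in this assay is 32000 nM, within a range from 18000 nM to 60000 nM, and most likely reported once more as a limit.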

Compound 4, half-maximal cytotoxic concentration: >= 25000 nM
Compound 4: only a limit was reported; the forecaster's own chance of this, stated with the estimate: 85%; the middle value is on the limit's open side.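

In this assay compound 4 gives >= 25000 nM, again a limit of the assay and not a number. Going by these compounds alone, with compound 1, compound 2 and compound 4 all reported only as limits, no step among them can be read. The compounds shown leave open whether 2-(pyridin-4-yl)ethoxy in place of 3-(4-fluorophenyl)propyl changes the tolerated concentration at all.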